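Replacing cyclohexylamino with methyl on a carbonyl carbon

A few compounds are considered here, and "the series" means these few. Any claim that something is new, unique, unknown or untested is made for them only; others in the source may bear on it.

compound 1 `O=C(NC1CCCCC1)c1cccn1-c1ccc2c(c1)B(O)OC2` gives > 10 ug/mL as a limit
compound 2 `COc1ccc(CNC(=O)c2cccn2-c2ccc3c(c2)B(O)OC3)cc1` gives > 10 ug/mL as a limit

In an ADME assay on L929 cells (Mus musculus) for cytotoxicity, read by resazurin assay, with a stated time of 72 h (a lower number here means a stronger inhibitor, a higher number a weaker inhibitor), compound 1 stands at > 10 ug/mL and this is a limit, not a number. Compound 2 stands at > 10 ug/mL and this too is only a limit. Going by the values given here, the series so far therefore offers the limit of > 10 ug/mL in this assay, at which 2 of the 2 values shown sit, and no measured number.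

Among the compounds with values here, compound 3 `CC(=O)c1cccn1-c1ccc2c(c1)B(O)OC2` keeps the core of compound 1 and carries methyl in place of cyclohexylamino on a carbonyl carbon as its one change. Within the data shown here, the only measured step bearing on this is a step that the two limits leave unreadable from compound 1 to compound 2 and it gives no size to carry over, although it too replaces cyclohexyl. Neither direction can be argued from these data. No shift beyond the scatter is expected, so the estimated move is a step that the limit leaves unreadable from compound 1 to compound 3 in this assay as a working figure. A report as a limit is again the likeliest outcome for the next measurement. For compound 3 the expected value is 15 ug/mL with an estimated range from 6 ug/mL to 40 ug/mL as the working bounds.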

Compound 3, half-maximal inhibitory concentration: > 10 ug/mL
Compound 3: a limit, no number; the forecaster's own chance of this, stated with the estimate: 75%; the middle value does not contradict the limit.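

Compound 3, like compound 1, is reported only as a limit in this assay, so no step can be read between the two, and the series rests on a single reported limit: the limit of > 10 ug/mL in this assay, at which 3 of the 3 values shown sit.

The compounds shown leave open whether replacing cyclohexylamino with methyl on a carbonyl carbon changes cytotoxicity at all.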